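A few compounds are considered here, and "the series" means these few. Any claim that something is new, unique, unknown or untested is made for them only; others in the source may bear on it.

Measured compounds:
compound 1 `CC(C)(C)N(NC(=O)c1ccccc1)C(=O)c1ccccc1Br` gives 170 nM in an assay on cells for agonist activity at ecdysone receptor (Bombyx mori), read by a luciferase reporter, with a stated time of 24 h; a lower number here means that less compound is needed, a higher number that more compound is needed for the effect
compound 2 `Cc1cc(C)cc(C(=O)N(NC(=O)c2ccccc2)C(C)(C)C)c1` gives 69.2 nM in this assay
compound 3 `Cc1cccc(C(=O)NN(C(=O)c2ccccc2Cl)C(C)(C)C)c1` gives 603 nM in this assay

Compound 3 gives the highest of the three numbers; compound 1 sits nearest to it and compound 2 furthest, both gaps beyond the scatter. Compound 4 `Cc1ccc(C)c(C(=O)NN(C(=O)c2ccccc2Cl)C(C)(C)C)c1` is not yet measured. It differs from compound 3 in one place: methyl in place of hydrogen on an aromatic carbon, the same difference cut one bond further out reading 3-methylphenyl to 2,5-dimethylphenyl.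

Among the measured compounds shown here, only one measured step stands, a 2.5-fold lower number from compound 1 to compound 2 (0.39 log units; beyond the scatter). It changes the other carbonyl-bearing ring and exchanges a halogen-bearing ring for a dimethyl-bearing one, so it speaks only loosely to a single added methyl on the ring carrying the 3-methyl group. For the measured compounds named here, compound 2 and compound 3 differ in two places at once, so their values show only that the compound carrying two methyl groups on one ring and an unsubstituted benzoyl gives the lower number. Going by the values given here, no measured pair isolates a methyl in place of hydrogen on this ring, so for this assay no step beyond the scatter is expected in either direction.

Compound 4 is therefore expected to give 450 nM, within 150 nM to 1400 nM, an expected step of a 1.3-fold lower number from compound 3 to compound 4 (0.13 log units; within the scatter).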

Compound 4, half-maximal effective concentration: 1620 nM
Beside the measured number, compound 4's estimate is 3.6-fold (0.56 log units) below it; measured number above the stated range.
By their numbers in this assay, from the lowest: compound 2; then compound 1; then compound 3; then compound 4.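

In this assay, methyl in place of hydrogen on the aromatic carbon ortho to a large group and para to a methyl group, reading 3-methylphenyl to 2,5-dimethylphenyl, gives a 2.7-fold higher number from compound 3 to compound 4 (0.43 log units; beyond the scatter), so this position does not tolerate the change without a shift beyond the scatter. Among the compounds shown here, this is the first step that isolates a single added methyl on this ring, and its direction is toward more compound being needed, whereas the only earlier step, a 2.5-fold lower number from compound 1 to compound 2 (0.39 log units; beyond the scatter), exchanged a bromine-bearing ring for a dimethyl-bearing one and says little about this carbon. Nothing available bears on why the number rises with this methyl.

Going by these compounds, whether the rise belongs to methyl alone or to any group on this carbon stays open, and a methoxy group or an amine there would help separate the two. Also open, on these data alone, is whether the same added methyl moves the number in the same direction when the other ring is the unsubstituted benzoyl of compound 2 rather than the chlorine-bearing ring of compound 4.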